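Methyl to bromo step carried onto a second core

The source may hold more compounds than are shown below. What is called first, only, known or untested is meant among the compounds shown, and "the series" means these compounds.

Measured compounds in a functional assay on L1210 cells (Mus musculus) for inhibition; on this read-out lower numbers stand for stronger inhibition and higher numbers for weaker inhibition:
compound 1, `Cc1ccccc1/C=C1\CCc2ccccc2C1=O`, 50200 nM
compound 2, `O=C1/C(=C/c2ccccc2Br)CCc2ccccc21`, 33400 nM
compound 3, `Cc1ccccc1/C=C1\Cc2ccccc2C1=O`, 208000 nM

Compound 1 and compound 2 share one core and differ by bromo in place of methyl on an aromatic carbon. That step, a 1.5-fold lower number from compound 1 to compound 2 (0.18 log units; within the scatter), is within the scatter, so the two values cannot be ordered.

Compound 3 carries the methyl on a different core; the difference between the two cores is not broken down here. In this assay compound 3 has the highest number of the three, and its gaps to compound 1 and to compound 2 are both beyond the scatter.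

Compound 4, `O=C1/C(=C/c2ccccc2Br)Cc2ccccc21`, is not yet measured. It differs from compound 3 by bromo in place of methyl on an aromatic carbon, the same change as from compound 1 to compound 2, with the place described in identical words. The expectation for compound 4 rests on compound 3 with 208000 nM and on the step of a 1.5-fold lower number from compound 1 to compound 2 (0.18 log units; within the scatter), which was within the scatter. A step of about a 1.5-fold lower number from compound 3 to compound 4 (0.17 log units; within the scatter) is therefore expected, also within the scatter, and compound 4 is estimated at 140000 nM in this assay, with 60000 nM to 350000 nM as the expected range.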

Compound 4, half-maximal inhibitory concentration: 64200 nM
Beside the measured number, compound 4's estimate is 2.2-fold (0.34 log units) above it; low and high end bracket the measured number.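

In this assay, bromo in place of methyl on an aromatic carbon gives a 3.2-fold lower number from compound 3 to compound 4 (0.51 log units; beyond the scatter), a modest step on the core of compound 3. Set beside the same change on the core of compound 1, this step cannot be told apart from the earlier one, so the change carries from one core to the other without a measurable difference: the same change on two cores in this assay, a 1.5-fold lower number (0.18 log units; within the scatter) from compound 1 to compound 2 and a 3.2-fold lower number (0.51 log units; beyond the scatter) from compound 3 to compound 4, 2.2-fold (0.33 log units) apart, within the scatter of two such steps. Going by these compounds alone, this does not show that the step is larger on the core of compound 3, and since only one of the two steps lies beyond the scatter, it does not show that the change lowers the number on every core, nor does a single pair of cores give a rule for the series.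

Only methyl and bromo stand at this place in the compounds shown, so the outcome with an amine, a carboxylic acid or a methoxy group there remains open. Also open, from the compounds shown here alone, is whether the same agreement between steps would hold on a third core.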